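Removing the bromo from the aryl piperazine of compound 2

A few compounds are considered here, and "the series" means these few. Any claim that something is new, unique, unknown or untested is made for them only; others in the source may bear on it.

Of the compounds shown here, two carry a number so far. Compound 2 `CCCn1c(=O)[nH]c2nc(-c3ccc(S(=O)(=O)N4CCN(c5cccc(Br)c5)CC4)cc3)[nH]c2c1=O` gives 27% in an assay on CHO cells for displacement of a labelled ligand from adenosine receptor A3 (Homo sapiens), read by scintillation counting, with a stated time of 45 min, tested at 1 uM, in the presence of a further agent that is not named here; on this read-out lower numbers stand for less inhibition and higher numbers for more inhibition at the one concentration tested (going by the name of the read-out). Its nearest neighbour is compound 1 `CCCn1c(=O)[nH]c2nc(-c3ccc(S(=O)(=O)N4CCN(c5ccccc5Br)CC4)cc3)[nH]c2c1=O`, which in this assay gives 20%, a number that lies within the scatter of compound 2. For the measured compounds named here, the single measured step, a number 7 percentage points higher from compound 1 to compound 2 (within the scatter), moves the bromo from one aromatic position to another and stays within the scatter. Compound 3 `CCCn1c(=O)[nH]c2nc(-c3ccc(S(=O)(=O)N4CCN(c5ccccc5)CC4)cc3)[nH]c2c1=O` differs from compound 2 by hydrogen in place of bromo on an aromatic carbon. No measured step removes the bromo altogether, so the change is only loosely covered by the one step shown, which itself did not reach beyond the scatter. For compound 3 no step beyond the scatter is therefore expected in this assay, the estimated step being a number 7 percentage points lower from compound 2 to compound 3 (within the scatter). Compound 3 is expected to give 20% in this assay, with a range from 5% to 38%.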

Compound 3, a percentage reported as inhibition, at one concentration (the size of the read-out at that concentration, not a potency): 27%
Estimate against measurement, compound 3: 7 percentage points below; the measured number falls inside the stated range.
By their numbers in this assay, from the lowest: compounds 1, 2 and 3 (each within the scatter of the next).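

Removing the bromo altogether in this assay (no change at the digits printed from compound 2 to compound 3 (within the scatter)) goes further than the earlier move of the bromo between ring positions, and it too stays within the scatter. The same change read against the other bromo compound (a number 7 percentage points higher from compound 1 to compound 3 (within the scatter)) also stays within the scatter, so for these three compounds, neither the bromo nor its placement separates the numbers on this aromatic ring. No accompanying measurement offers an explanation for this flat result.

From the compounds shown here alone, whether any group on this ring can move the number beyond the scatter remains open, since a methoxy, an amine or a carboxylic acid has no reading here. Going by these compounds, the effect of a longer chain on the shared core, or of replacing the piperazine, is equally open.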